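The source may hold more compounds than are shown below. What is called first, only, known or untested is meant among the compounds shown, and "the series" means these compounds.

In a functional assay on the whole organism (strain Wistar) for inhibition, with Rattus norvegicus as the target, read by paw edema, with stated times of 30 min and 5 h, at a dose of 0.05 mmol/kg by the oral route (a higher number here means more inhibition at the dose given (going by the name of the read-out), a lower number less inhibition), compound 1 `CS(=O)(=O)c1ccc(N2N=C(c3ccccc3)CCC2=O)cc1` gives 47.3%, and compound 2 `CS(=O)(=O)c1ccc(N2N=C(c3ccc(Oc4ccccc4)cc3)CCC2=O)cc1` gives 65.7%, the higher of the two numbers, with compound 1 the nearest; the step is a number 18.4 percentage points higher from compound 1 to compound 2 (beyond the scatter). Compound 3 `CC(C)(C)c1ccc(C2=NN(c3ccc(S(C)(=O)=O)cc3)C(=O)CC2)cc1` differs from compound 2 by tert-butyl in place of phenoxy on an aromatic carbon. Within the data shown here, no measured step swaps one substituent for another here; the only step with a bearing is a number 18.4 percentage points higher from compound 1 to compound 2 (beyond the scatter), which shows that a substituent at this carbon lifts the read-out. The expected step is a number 7.7 percentage points lower from compound 2 to compound 3 (within the scatter), a small downward shift within the scatter. Compound 3 is therefore estimated at 58%, with a range from 40% to 74%.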

Compound 3, a percentage reported as inhibition, in the whole organism at one dose (the size of the read-out at that dose, not a potency): 68.4%
Estimate against measurement, compound 3: 10.4 percentage points below; the range from low to high includes it.
By their numbers in this assay, from the lowest: compound 1; then compounds 2 and 3 (each within the scatter of the next).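

Working from this assay, the change to tert-butyl gives a number 2.7 percentage points higher from compound 2 to compound 3 (within the scatter) and so shows that the aromatic ring and oxygen of phenoxy are not required to keep the read-out at this carbon. Tert-butyl in place of hydrogen gives a number 21.1 percentage points higher from compound 1 to compound 3 (beyond the scatter) and so shows that the lift is not confined to phenoxy, since two quite different groups on this carbon both provide it.

Still open, from the compounds shown here alone, is whether a small group such as methyl or a chlorine atom, or an amine or a carboxylic acid, at this carbon would keep the lift. No supporting data are available to explain either step.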